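Replacing a Direct Aryl Link by an Aryl Ether

The source may hold more compounds than are shown below. What is called first, only, known or untested is meant among the compounds shown, and "the series" means these compounds.

Within the data shown here, compound 1, with the structure `COc1ccccc1-c1ccc([C@H]2S[C@@H](C)C(=O)Nc3c2c(C)nn3-c2ccccc2C)cc1`, is the stronger of the two compounds measured so far. In an assay on isolated protein for agonist activity at Bile acid receptor (Homo sapiens), read by AlphaScreen, with a stated time of 30 min (on this read-out lower numbers stand for an effect already at smaller amounts and higher numbers for an effect only at larger amounts of compound), compound 1 gives 1100 nM. Compound 2, with the structure `Cc1cccc(-n2nc(C)c3c2NC(=O)[C@H](C)S[C@@H]3c2ccc(Oc3ccccc3)cc2)c1`, differs from compound 1 in more than one place, and in this assay compound 2 gives 2400 nM; the gap between these two values lies beyond the scatter of the assay, so compound 1 stands at the lowest number shown.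

The unmeasured compound 3 has the structure `COc1ccccc1Oc1ccc([C@H]2S[C@@H](C)C(=O)Nc3c2c(C)nn3-c2ccccc2C)cc1`. It differs from compound 1 in a single change: 2-methoxyphenoxy in place of 2-methoxyphenyl on an aromatic carbon. Among the measured compounds shown here, no pair of measured compounds shows this change alone, so its size can only be guessed. Compound 2 also carries an aryl ether in this part of the molecule and remains active, which suggests the ether is tolerated, though compound 2 carries a second change as well. A modest weakening is expected, with the step of a 1.6-fold higher number from compound 1 to compound 3 (0.21 log units; within the scatter) from compound 1 to compound 3 at or just beyond the scatter. For compound 3 the expected value is 1800 nM, with a range from 700 nM to 4500 nM.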

Compound 3, half-maximal effective concentration: 1700 nM
Estimate against measurement, compound 3: 1.1-fold (0.02 log units) above; measured number inside the range.
By their numbers in this assay, from the lowest: compounds 1, 3 and 2 (each within the scatter of the next, the first and the last beyond it).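

In this assay, 2-methoxyphenoxy in place of 2-methoxyphenyl on an aromatic carbon, para to a large group, gives a 1.5-fold higher number from compound 1 to compound 3 (0.19 log units; within the scatter), so this assay cannot tell the two compounds apart. Among these compounds, this is the first direct reading of this single change, and it shows that at this position the methoxy-bearing ring can be joined to the core either directly or through an ether oxygen without a difference that stands clear of the usual scatter between repeated measurements. The data shown offer no separate measurement that could explain this result.

The compounds shown leave open how much the link itself can vary, for example whether a longer chain between the two rings, or an amine nitrogen in place of the ether oxygen, would also give a number close to those of compound 1 and compound 3. They also leave open what the methoxy group contributes, which a close analogue carrying a carboxylic acid in its place on the same ring could begin to answer.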